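This account rests on a few compounds, and the source may have more. Where it says the series, first, only, none or still open, it means among the compounds named here.

Working notes on a short series in a functional assay on A549 cells (Homo sapiens) for cytotoxicity, read by MTT assay, with a stated time of 48 h; a lower number here means a stronger inhibitor, a higher number a weaker inhibitor. Compound 1 `C#CCSc1nnc(C)n1N1C(=O)c2ccccc2C1=O` and compound 2 `C#CCSc1nnc(-c2cc(OC)c(OC)c(OC)c2)n1N1C(=O)c2ccccc2C1=O` share one core with the propargylsulfanyl group on it. In this assay compound 1 reaches only the limit > 200000 nM, which is not a number. In this assay compound 2 likewise stops at the limit > 200000 nM. For the measured compounds named here, compound 2 therefore stands at a limit rather than at a value, and the one further value known is also a limit: the limit of > 200000 nM in this assay, at which 2 of the 2 values shown sit. Going by the values given here, no step between measured compounds can be sized.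

Compound 3 `COc1cc(-c2nnc(SCC(=O)c3ccc(Br)cc3)n2N2C(=O)c3ccccc3C2=O)cc(OC)c1OC` differs from compound 2 in one place: (4-bromophenyl)carbonyl in place of ethynyl on a saturated chain carbon bound to a sulfur. Cut one bond further out, propargylsulfanyl in compound 2 becomes (((4-bromophenyl)carbonyl)methyl)sulfanyl in compound 3. Among the compounds with values here, no measured step informs this change, because both values known sit at the limit of > 200000 nM in this assay, at which 2 of the 2 values shown sit. The step is expected to be an at least 1.6-fold lower number from compound 2 to compound 3 (0.22 log units; that floor lies within the scatter), toward a stronger inhibitor, without support from any measured pair. Compound 3 is estimated in this assay at 120000 nM. For compound 3 the expected range runs from 30000 nM to 400000 nM, with a fair chance that only a limit is reported.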

Compound 3, half-maximal inhibitory concentration: 16100 nM
The estimate for compound 3 lay 7.5-fold (0.87 log units) above the measured number, and the stated range ends above it.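

In this assay, for the compounds shown here, the chain on the sulfur is the first place where a change gives a measured number: with (((4-bromophenyl)carbonyl)methyl)sulfanyl in place of propargylsulfanyl, the result is an at least 12-fold lower number from compound 2 to compound 3 (1.09 log units; beyond the scatter). This step is a floor and not a full size, as the starting point in compound 2 is a limit and not a number, and the two propargylsulfanyl compounds remain the only ones at that limit: the limit of > 200000 nM in this assay, at which 2 of the 3 values shown sit. The sulfur-bound group therefore has a demonstrable bearing on the read-out on this shared core, with a change that brings in an aromatic ring, a carbonyl and a bromine together.

Going by these compounds alone, the single step does not separate the contributions of the carbonyl, the phenyl ring and the bromine, so it remains open whether a plain phenylcarbonyl, a 4-methoxyphenylcarbonyl or a simple benzyl group on the sulfur would hold the number of compound 3. Also open, from the compounds shown here alone, are how an amine or a carboxylic acid at this place would read, and whether the same change on the core of compound 1, with its methyl group, would leave the limit.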